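The compounds below may be only part of what the source reports. "The series", "measured", "known", "first", "only" and "open" are said of these compounds alone.

Measured compounds in a functional assay on HeLa cells (Homo sapiens) for antiproliferative activity, read by sulforhodamine B assay, with a stated time of 72 h; a lower number here means a stronger inhibitor, a higher number a weaker inhibitor:
compound 1 `COc1cccc(NC(=S)N/N=C/c2ccc3ccccc3n2)c1`: 74500 nM
compound 2 `Cc1ccc(NC(=O)N/N=C/c2ccc3ccccc3n2)cc1`: limit only
compound 3 `Cc1csc2sc(/C=N/NC(N)=S)c(C)c12`: 1120 nM.

For compound 2 the assay gives only its limit, > 100000 nM, which is a limit and not a number (the limit of > 100000 nM in this assay, at which 1 of the 3 values shown sits). Among the measured compounds shown here, of the two numbers, compound 1 gives the higher one; compound 3 lies beyond the scatter from it, and no single-change step connects the two. Compound 4 `S=C(N/N=C/c1ccc2ccccc2n1)Nc1ccccc1` differs from compound 1 by hydrogen in place of methoxy on an aromatic carbon. For the measured compounds named here, no measured pair shows such a step. In this assay the step is expected to be small, in either direction or none beyond the scatter. Compound 4 is expected at 60000 nM, between 20000 nM and 150000 nM. The expected step is a 1.2-fold lower number from compound 1 to compound 4 (0.09 log units; within the scatter).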

Compound 4, half-maximal inhibitory concentration: 27400 nM
The estimate for compound 4 lay 2.2-fold (0.34 log units) above the measured number; low and high end bracket the measured number.
By their numbers in this assay, from the lowest: compound 3; then compound 4; then compound 1. At a limit, above all of these: compound 2.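

In this assay, among the compounds shown here, going from 3-methoxyphenyl to phenyl gives a 2.7-fold lower number from compound 1 to compound 4 (0.43 log units; beyond the scatter) as the only measured step at this position. The methoxy group is therefore not required for the activity measured here, and hydrogen in its place gives a modest gain. Nothing shown gives a cause for this step.

With one step at one position, there is no telling whether this holds for other groups. As far as these compounds go, an amine, a fluorine or a longer alkoxy chain at this place remains open, as does the same change at other places on the ring.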